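The source may report more compounds than this note shows. Statements on the series, on what has been measured and on what is new or still open speak of the compounds shown alone.

In a functional assay on MGC-803 cells (Homo sapiens) for inhibition, read by sulforhodamine B assay (on this read-out higher numbers stand for weaker inhibition and lower numbers for stronger inhibition), compound 2 `O=C1C(Nc2cccc(Cl)c2)=CC(=O)c2c1nc1n2[C@H]2OC[C@@H](O)[C@H]2OC1` gives 1530 nM. Going by the values given here, compound 1 `Cc1ccc(NC2=CC(=O)c3nc4n(c3C2=O)[C@H]2OC[C@@H](O)[C@H]2OC4)cc1C` gives 860 nM in this assay, a number that lies within the usual scatter of the one for compound 2, so the two cannot be told apart. Compound 3 `O=C1C=C(NC2CCCC2)C(=O)c2c1nc1n2[C@H]2OC[C@@H](O)[C@H]2OC1` gives the limit of > 8000 nM in this assay, not a number. Compound 4 `O=C1C(NC2CCCCC2)=CC(=O)c2c1nc1n2[C@H]2OC[C@@H](O)[C@H]2OC1` has not yet been measured. It differs from compound 2 in one place: cyclohexyl in place of 3-chlorophenyl on an amine nitrogen. Among the compounds with values here, the one measured step of the same kind is an at least 9.3-fold higher number from compound 1 to compound 3 (0.96 log units; beyond the scatter), where an aromatic ring on the amine nitrogen was likewise exchanged for a non-aromatic ring of carbon only, and the number rose beyond the scatter to the limit (the limit of > 8000 nM in this assay, at which 1 of the 3 values shown sits). A step of similar kind is therefore expected here, in the direction of weaker inhibition, and likely large enough that compound 4 may itself reach the limit. Compound 4 is estimated at 12000 nM, between 4000 nM and 40000 nM. The step this estimate expects is a 7.8-fold higher number from compound 2 to compound 4 (0.89 log units; beyond the scatter).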

Compound 4, half-maximal inhibitory concentration: > 8000 nM
Compound 4: a limit, no number; the forecaster's own chance of this, stated with the estimate: 60%; the middle value lies beyond the limit too.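

Exchanging an aromatic ring on the amine nitrogen for a non-aromatic ring of carbon only has now weakened inhibition in a second pair, in this assay, with an at least 5.2-fold higher number from compound 2 to compound 4 (0.71 log units; beyond the scatter). The earlier loss is therefore not tied to 3,4-dimethylphenyl and cyclopentyl alone: it recurs with 3-chlorophenyl and cyclohexyl, and neither pair goes against it. Compound 4, like compound 3, ends at a limit and not a number, so the full size of neither step is known: the limit of > 8000 nM in this assay, at which 2 of the 4 values shown sit.

On these data alone, what remains open is how far this preference for an aromatic ring extends. A pyridyl ring, a benzyl group or an open butyl chain on the same nitrogen could show whether a ring directly on the nitrogen is needed, and whether that ring must be aromatic.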